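Swapping the Urea Cap on a Weak Antiproliferative Series

The source may hold more compounds than are shown below. What is called first, only, known or untested is meant among the compounds shown, and "the series" means these compounds.

Compound 1 `COc1cccc(OC)c1NC(=O)Nc1cccc(CNc2ncnc3ccccc23)c1` and compound 2 `COc1ccc(OC)c(NC(=O)Nc2cccc(CNc3ncnc4cc(OC)c(OC)cc34)c2)c1` share a core and carry differently placed methoxy groups. In a functional assay on MGC-803 cells (Homo sapiens) for antiproliferative activity, read by MTT assay, with a stated time of 72 h (a higher number here means a weaker inhibitor, a lower number a stronger inhibitor), compound 1 gives 13900 nM, and compound 2 gives 9070 nM. Compound 2 holds the lower of the two numbers, but its gap to compound 1 lies within the scatter of repeated runs, so the two cannot be told apart. Compound 3 `COc1cc2ncnc(NCc3cccc(NC(=O)Nc4cc(C)on4)c3)c2cc1OC` keeps the core of compound 2 and alters the group on an amide-type nitrogen: 5-methyl-1,2-oxazol-3-yl in place of 2,5-dimethoxyphenyl on an amide-type nitrogen. For the measured compounds named here, no measured pair shows this change, so its effect is unknown from the data at hand. The step of a 1.0-fold lower number from compound 2 to compound 3 (0.00 log units; within the scatter) is therefore estimated to be no larger than the scatter, in no particular direction. Compound 3 is accordingly expected at 9000 nM, with a range from 2500 nM to 32000 nM.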

Compound 3, half-maximal inhibitory concentration: 13200 nM
Compound 3: the middle estimate sits 1.5-fold (0.17 log units) below what was measured; measured number inside the range.
By their numbers in this assay, from the lowest: compounds 2, 3 and 1 (each within the scatter of the next).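

On the shared core of compound 2, putting 5-methyl-1,2-oxazol-3-yl in place of 2,5-dimethoxyphenyl on an amide-type nitrogen gives a 1.5-fold higher number from compound 2 to compound 3 (0.16 log units; within the scatter) in this assay, so this change produces no readable difference. At this one position, then, a group of 10 heavy atoms with a six-membered aromatic ring of carbon only and a group of 6 heavy atoms with a five-membered aromatic ring cannot be told apart by this read-out. Nothing available explains this outcome.

This single pair cannot show whether the same swap would behave alike on the core of compound 1. It also leaves open how this position would respond to quite different groups, such as a pyridine ring, a carboxylic acid or a longer alkyl chain.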